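Lengthening the amine substituent on a chlorinated biaryl

The source may report more compounds than this note shows. Statements on the series, on what has been measured and on what is new or still open speak of the compounds shown alone.

Among the compounds with values here, compound 3 `CCNCc1ccc(Cl)c(-c2ccccc2OC)c1` gives 210 nM in an assay on isolated protein for binding affinity to 5-hydroxytryptamine receptor 1B (Homo sapiens) (on this read-out lower numbers stand for stronger inhibition and higher numbers for weaker inhibition), the lowest of the three numbers measured so far; compound 1 `COc1ccccc1-c1cc(C2CCNC2)ccc1Cl` gives 410 nM and compound 2 `CNCc1ccc(Cl)c(-c2ccccc2OC)c1` gives 1200 nM. The step of a 2.0-fold lower number from compound 1 to compound 3 (0.29 log units; within the scatter) lies within the scatter, whereas a 5.7-fold lower number from compound 2 to compound 3 (0.76 log units; beyond the scatter) lies beyond it. Compound 4 `CCCCNCc1ccc(Cl)c(-c2ccccc2OC)c1` differs from compound 3 by ethyl in place of hydrogen on a saturated chain carbon, two bonds along the chain from an amine nitrogen. Within the data shown here, only one measured step bears directly on this change, namely a 5.7-fold lower number from compound 2 to compound 3 (0.76 log units; beyond the scatter), where a shorter extension of the same amine substituent lowered the number. A further lowering of modest size is therefore expected, a 1.4-fold lower number from compound 3 to compound 4 (0.15 log units; within the scatter), though with real uncertainty about whether the trend continues. Compound 4 is estimated at 150 nM, with a range of 50 nM to 500 nM.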

Compound 4, inhibition constant: > 10000 nM
Compound 4: a limit, no number; the forecaster's own chance of this, stated with the estimate: 2%; middle value at least 66-fold (1.82 log units) from the limit.
By their numbers in this assay, from the lowest: compounds 3 and 1 (each within the scatter of the next); then compound 2. At a limit, above all of these: compound 4.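

Chain length on this amine does not act in one direction: ethylamino to butylamino reverses the lowering seen when the chain first grew, and sharply (an at least 47-fold higher number from compound 3 to compound 4 (1.67 log units; beyond the scatter)). The butylamino compound also stands well clear of the other two amines (an at least 8.3-fold higher number from compound 2 to compound 4 (0.92 log units; beyond the scatter); an at least 24-fold higher number from compound 1 to compound 4 (1.38 log units; beyond the scatter)). Its read-out is a limit of the assay and not a number: the limit of > 10000 nM in this assay, at which 1 of the 4 values shown sits.

The compounds shown leave open whether a propylamino chain still holds the level of the ethylamino compound or already loses it. They also leave open how a branched chain, such as isopropylamino, would behave on the same core.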